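Ethyl in Place of Acetyl on the Ring Nitrogen

A few compounds are considered here, and "the series" means these few. Any claim that something is new, unique, unknown or untested is made for them only; others in the source may bear on it.

Of the compounds shown here, three built on a shared core have been measured in a functional assay on the whole organism with Canis familiaris (Canis lupus familiaris) as the target, at a dose of 8 mg/kg by the oral route; a higher number here means a stronger effect of the compound at the dose given, a lower number a weaker effect. Compound 1 `CCc1nc2c(OCc3ccccc3)cccn2c1N` gives 59%. Compound 2 `Cc1nc2c(OCc3ccccc3)cccn2c1CN` gives 9%. Compound 3 `CC(=O)Nc1c(C)nc2c(OCc3ccccc3)cccn12` gives 44%, the second highest of the three numbers: compound 1 lies higher and compound 2 lower, both gaps beyond the scatter. Among the compounds with values here, the only measured step between neighbours, a number 35 percentage points higher from compound 2 to compound 3 (beyond the scatter), is an exchange of acetamido for aminomethyl on an aromatic carbon and is large.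

Compound 4 `CCNc1c(C)nc2c(OCc3ccccc3)cccn12` differs from compound 3 by ethyl in place of acetyl on a nitrogen on an aromatic ring. Within the data shown here, no measured step exchanges acetyl for ethyl on a nitrogen on an aromatic ring, so the step from compound 2 to compound 3 bears on it only indirectly, through the acetamido that compound 3 carries and compound 4 loses. Compound 4 keeps the ethylamino on the same ring carbon, and the two flanking numbers, compound 1 and compound 3, differ by a modest margin. Compound 4 is therefore expected to show about a number 1 percentage points higher from compound 3 to compound 4 (within the scatter), a step within the scatter. The estimate for compound 4 is 45%, with a range from 15% to 75%.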

Compound 4, a percentage reported as inhibition, in the whole organism at one dose (the size of the read-out at that dose, not a potency): 68%
For compound 4 the middle estimate is 23 percentage points below the measured one; low and high end bracket the measured number.
By their numbers in this assay, from the lowest: compound 2; then compound 3; then compounds 1 and 4 (each within the scatter of the next).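

The acetyl on this nitrogen turns out to matter: with the ring carbon, its nitrogen and the rest of the core unchanged, ethyl in its place gives a clear gain in this assay (a number 24 percentage points higher from compound 3 to compound 4 (beyond the scatter)). The same comparison extends the earlier step on the aromatic carbon, since ethylamino in place of aminomethyl (a number 59 percentage points higher from compound 2 to compound 4 (beyond the scatter)) goes well beyond what acetamido achieved (a number 35 percentage points higher from compound 2 to compound 3 (beyond the scatter)), so the group on that nitrogen shapes the effect and not only the presence of a nitrogen on the carbon. Nothing available explains why ethyl outperforms acetyl here.

The compounds shown leave open whether a propyl or a methyl on this nitrogen, or the free amine on the same core, would match compound 4. With a single oral dose, they also leave open how compound 4 would behave at other doses.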